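Hydroxy Addition and Cell Tolerance Across Two Cores

The source may hold more compounds than are shown below. What is called first, only, known or untested is meant among the compounds shown, and "the series" means these compounds.

Compound 1 `O=[N+]([O-])C1=NNc2nc(C(F)(F)F)nn2C1c1ccc(O)cc1O` gives 108000 nM in an ADME assay on MDCK cells (Canis lupus familiaris) for cytotoxicity; a higher number here means that more compound is tolerated, a lower number that less compound is tolerated.
Compound 2 `O=[N+]([O-])C1=CNc2nc(-c3ccco3)nn2C1c1ccc(O)cc1O` gives 119000 nM in this assay.
Compound 3 `O=[N+]([O-])C1=NNc2nc(C(F)(F)F)nn2C1c1ccc(O)c(O)c1O` gives 67000 nM in this assay.

The difference between the cores of compound 1 and compound 2 is not broken down here. Compound 3 differs from compound 1 by hydroxy in place of hydrogen on an aromatic carbon. That change made a 1.6-fold lower number from compound 1 to compound 3 (0.21 log units; within the scatter). Compound 4 `O=[N+]([O-])C1=CNc2nc(-c3ccco3)nn2C1c1c(O)cc(O)cc1O`, not yet measured, differs from compound 2 by hydroxy in place of hydrogen on an aromatic carbon. This is the same kind of change, yet the surroundings differ: in compound 3 the entering group is ortho to two hydroxy groups and meta to a large group, whereas in compound 4 it is ortho to a large group and meta to two hydroxy groups. For the measured compounds named here, the step from compound 2 to compound 4 in this assay is expected to resemble the earlier step, because a 1.6-fold lower number from compound 1 to compound 3 (0.21 log units; within the scatter) is the only measured example of this kind of change. The expected step is a 1.5-fold lower number from compound 2 to compound 4 (0.17 log units; within the scatter). Compound 4 is therefore estimated to give about 80000 nM, most likely between 45000 nM and 150000 nM.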

Compound 4, half-maximal cytotoxic concentration: 280000 nM
Compound 4: middle estimate off by 3.5-fold (0.54 log units), on the low side, outside the stated range (above it).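

In this assay, putting a hydroxy in place of a hydrogen on the aromatic ring gave a 2.4-fold higher number from compound 2 to compound 4 (0.37 log units; beyond the scatter). Set beside the earlier step, this shows that the result of the change on one core cannot simply be carried over to the other core in this series: the same change on two cores in this assay, a 1.6-fold lower number (0.21 log units; within the scatter) from compound 1 to compound 3 and a 2.4-fold higher number (0.37 log units; beyond the scatter) from compound 2 to compound 4, 3.8-fold (0.58 log units) apart, beyond the scatter of two such steps It does not show what sets the two steps apart: the cores differ, the entering hydroxy also takes a different place on the ring in each pair, and a single pair on each core cannot separate these two differences.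

Still open, from the compounds shown here alone, is whether a hydroxy placed as in compound 4, ortho to a large group and meta to two hydroxy groups, would give a similar step on the core of compound 1. Also open, going by these compounds, is how another small group at that same place, such as an amine or a carboxylic acid, would compare with the hydroxy of compound 4.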